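Solubility notes: amide for sulfonamide on the shared core

A few compounds are considered here, and "the series" means these few. Any claim that something is new, unique, unknown or untested is made for them only; others in the source may bear on it.

Compound 1 `CNS(=O)(=O)c1ccc(-c2cnc(N)c(-c3ccc(OC)nc3)c2)cc1` is the starting point. In a physicochemical assay for solubility, read by nephelometry, measured as kinetic solubility, at pH 2 (a higher number here means a more soluble compound, a lower number a less soluble compound), compound 1 gives > 100 ug/mL, which is a limit of the assay and not a number. Compound 2 `COc1ccc(-c2cc(-c3ccc(S(C)(=O)=O)cc3C(F)(F)F)cnc2N)cn1` gives > 100 ug/mL in this assay, again a limit. Compound 3 `COc1ccc(-c2cnc(N)c(-c3ccc(OC)nc3)c2)cn1` gives > 100 ug/mL in this assay, also a limit. All three values sit at the limit of > 100 ug/mL in this assay, at which 3 of the 3 values shown sit, so compound 1 cannot be ranked against its neighbours. Compound 4 `COc1ccc(-c2cc(-c3ccc(C(=O)N(C)C)cc3)cnc2N)cn1` differs from compound 1 by dimethylcarbamoyl in place of methylsulfamoyl on an aromatic carbon. Among the compounds with values here, no measured step matches this change, so its size is unknown. The step of a number no higher from compound 1 to compound 4 (the limit leaves the size open) is expected to stay within the scatter. Compound 4 is estimated at 100 ug/mL, in a range from 40 ug/mL to 150 ug/mL, most likely again reported as a limit.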

Compound 4, solubility: > 100 ug/mL
Compound 4 ended at the assay's limit (the forecaster's own chance of this, stated with the estimate: 75%); the middle value lies on the limit itself.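

Within the data shown here, compound 1 and compound 4 both sit at a limit in this assay, so no step between them can be read: the limit of > 100 ug/mL in this assay, at which 4 of the 4 values shown sit. The compounds shown leave open how these four rank against one another in this assay.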